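A few compounds are considered here, and "the series" means these few. Any claim that something is new, unique, unknown or untested is made for them only; others in the source may bear on it.

Measured so far in an assay on isolated protein for displacement of a labelled ligand from metabotropic glutamate receptor 5 (Homo sapiens), with a stated time of 60 min, tested at 1 uM; a lower number here means less inhibition, a higher number more inhibition at the concentration tested (going by the name of the read-out):

compound 1 `CC1CCN(c2c(S(=O)(=O)c3ccc(C#N)cc3)cnc3cc(Cl)ccc23)CC1` gives 70%
compound 2 `COc1cccc(S(=O)(=O)c2cnc3cc(Cl)ccc3c2N2CCC(C)CC2)c1` gives 93%
compound 3 `Cc1ccc(S(=O)(=O)c2cnc3cc(Cl)ccc3c2N2CCC(C)CC2)cc1Cl` gives 89%

Compound 3 stands second highest of the three: nearest to compound 2, with a step of a number 4 percentage points lower from compound 2 to compound 3 (within the scatter), and furthest from compound 1, which lies below it by a number 19 percentage points higher from compound 1 to compound 3 (beyond the scatter). The two substituted phenyl groups on the sulfonyl sulfur in compound 2 and compound 3 thus read alike in this assay, while the 4-cyanophenyl of compound 1 reads lower, as a number 23 percentage points higher from compound 1 to compound 2 (beyond the scatter) also shows.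

Compound 4 `Cc1ccc(S(=O)(=O)c2cnc3cc(Cl)ccc3c2N2CCC(C)CC2)cc1C` differs from compound 3 by methyl in place of chloro on an aromatic carbon. Among the measured compounds shown here, no measured step exchanges chloro for methyl; the only bearing step is a number 4 percentage points lower from compound 2 to compound 3 (within the scatter), where a change of the group on the same aromatic ring stayed within the scatter. A step within the scatter is therefore expected, a number 2 percentage points lower from compound 3 to compound 4 (within the scatter). Compound 4 is estimated at 87%, in the range 74% to 96%.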

Compound 4, a percentage reported as inhibition, at one concentration (the size of the read-out at that concentration, not a potency): 86%
Compound 4: middle estimate off by 1 percentage points, on the high side; the range from low to high includes it.
By their numbers in this assay, from the lowest: compound 1; then compounds 4, 3 and 2 (each within the scatter of the next).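

In this assay methyl in place of chloro on this aromatic carbon, ortho to a methyl group, gives a number 3 percentage points lower from compound 3 to compound 4 (within the scatter) and so leaves the reading unchanged within the scatter. The 3,4-dimethylphenyl group also reads alike with 3-methoxyphenyl, at a number 7 percentage points lower from compound 2 to compound 4 (within the scatter) and stands clear of 4-cyanophenyl, at a number 16 percentage points higher from compound 1 to compound 4 (beyond the scatter) and this leaves compounds 2, 3 and 4 together with compound 1 alone apart. No measurement at hand explains these readings.

Still open, going by these compounds, is how an amine or a carboxylic acid in place of chloro at this position would read, since both groups compared here are single-atom substituents. Also open, on these data alone, is whether the lower reading of compound 1 belongs to the nitrile itself or to where it sits on the ring.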